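A few compounds are considered here, and "the series" means these few. Any claim that something is new, unique, unknown or untested is made for them only; others in the source may bear on it.

For the measured compounds named here, in a functional assay on KB cells (Homo sapiens) for cytotoxicity (on this read-out lower numbers stand for stronger inhibition and higher numbers for weaker inhibition), compound 1 (`COc1ccc(S(=O)(=O)N2CCc3cccc(NC(C)=O)c32)cc1`) gives 89 nM, while compound 2 (`COc1ccc(S(=O)(=O)N2CCc3cccc(NS(=O)(=O)c4ccccc4)c32)cc1`) gives 650 nM, the higher of the two numbers so far. Going by the values given here, the only measured step, a 7.3-fold higher number from compound 1 to compound 2 (0.86 log units; beyond the scatter), is modest but beyond the scatter, and it puts phenylsulfonyl in place of acetyl on a nitrogen on an aromatic ring. Compound 3 (`COc1ccc(C(=O)Nc2cccc3c2N(S(=O)(=O)c2ccc(OC)cc2)CC3)cc1`) changes that same nitrogen again: (4-methoxyphenyl)carbonyl in place of phenylsulfonyl on a nitrogen on an aromatic ring. Like compound 1, it carries a carbonyl there, so that measured step bears directly on this change, although no measured compound carries (4-methoxyphenyl)carbonyl. A partial return towards lower numbers is therefore expected in this assay, somewhat smaller than the measured step. The estimated change is a 4.3-fold lower number from compound 2 to compound 3 (0.64 log units; beyond the scatter). For compound 3 the expected value is 150 nM, with an estimated range of 30 nM to 700 nM.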

Compound 3, half-maximal inhibitory concentration: 2600 nM
The estimate for compound 3 lay 17-fold (1.24 log units) below the measured number, and the stated range ends below it.
By their numbers in this assay, from the lowest: compound 1; then compound 2; then compound 3.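

In this assay, a carbonyl on this nitrogen does not by itself restore the lower number: (4-methoxyphenyl)carbonyl in place of phenylsulfonyl gives a 4.0-fold higher number from compound 2 to compound 3 (0.60 log units; beyond the scatter), so the carbonyl shared with compound 1 does not set the level here. With the carbonyl kept, 4-methoxyphenyl in place of methyl on the carbonyl carbon gives a 29-fold higher number from compound 1 to compound 3 (1.47 log units; beyond the scatter), which shows that what the carbonyl carries matters at least as much as the carbonyl itself, and the acetyl of compound 1 keeps the lowest number of the three. No evidence is at hand to explain this order.

The compounds shown leave open whether the methoxy or the aromatic ring accounts for the rise, which a plain benzoyl would separate. They also leave open how a propanoyl chain, or the free amine on this nitrogen, would compare with the acetyl.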